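This account rests on a few compounds, and the source may have more. Where it says the series, first, only, none or still open, it means among the compounds named here.

Working notes on the series. Compound 1 `CC(O)(CSc1ccc(F)cc1)c1nc(-c2ccc(Cl)cc2)no1` and compound 2 `CC(O)(CSc1ccc(Cl)cc1)c1nc(-c2ccc(Cl)cc2)no1` share one core; compound 3 `CC(O)(CS(=O)(=O)c1ccc(F)cc1)c1nc(-c2ccccc2)no1` and the not yet measured compound 4 `CC(O)(CS(=O)(=O)c1ccc(Cl)cc1)c1nc(-c2ccccc2)no1` share another, and the difference between the two cores is not broken down here. In a functional assay on DU-145 cells (Homo sapiens) for cytotoxicity, read by MTT assay (on this read-out higher numbers stand for weaker inhibition and lower numbers for stronger inhibition), compound 1 gives 36300 nM, and compound 2 gives 14500 nM. The change between them, (chloro in place of fluoro on an aromatic carbon), produced a 2.5-fold lower number from compound 1 to compound 2 (0.40 log units; beyond the scatter). For compound 3 the value in this assay is only a limit, > 100000 nM; the evidence here is the limit of > 100000 nM in this assay, at which 1 of the 3 values shown sits. The change from compound 3 to compound 4 is the same one, (chloro in place of fluoro on an aromatic carbon), on the same place. Since compound 3 sits at a limit, the step to compound 4 cannot be reckoned from a number; if the chloro for fluoro exchange behaves as it did from compound 1 to compound 2 with a 2.5-fold lower number from compound 1 to compound 2 (0.40 log units; beyond the scatter), a modest downward move is expected, and compound 4 is estimated at 80000 nM (30000 nM to 200000 nM), which is an expected step of an at least 1.2-fold lower number from compound 3 to compound 4 (0.09 log units; that floor lies within the scatter), with a real chance that this assay again reports only a limit.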

Compound 4, half-maximal inhibitory concentration: > 100000 nM
Compound 4: no number, only a limit; the forecaster's own chance of this, stated with the estimate: 55%; middle value at least 1.2-fold (0.09 log units) from the limit.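

Compound 3 and compound 4 both give only a limit in this assay, so the chloro for fluoro step between them cannot be read: the limit of > 100000 nM in this assay, at which 2 of the 4 values shown sit.

The compounds shown leave open whether chloro in place of fluoro changes the read-out on the core of compound 3 as it did on the core of compound 1.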